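A smaller group on the five-membered ring: what to expect

The compounds below may be only part of what the source reports. "The series", "measured", "known", "first", "only" and "open" are said of these compounds alone.

Measured compounds:
compound 1 `O=C1O[C@H]([C@@H](O)Cn2cc(-c3cccc(O)c3)nn2)C(OCc2ccccc2)=C1OCc1ccccc1`: 54100 nM
compound 2 `O=C1O[C@H]([C@@H](O)Cn2cc(-c3cc(F)cc(F)c3)nn2)C(OCc2ccccc2)=C1OCc1ccccc1`: 62400 nM
compound 3 `O=C1O[C@H]([C@@H](O)Cn2cc(CNS(=O)(=O)c3ccc(F)cc3)nn2)C(OCc2ccccc2)=C1OCc1ccccc1`: 34700 nM

All of these numbers come from a functional assay on CFPAC-1 cells (Homo sapiens) for antiproliferative activity, read by MTT assay, with a stated time of 72 h; on this read-out lower numbers stand for stronger inhibition and higher numbers for weaker inhibition. Compound 3 carries the lowest number of the three, yet none of the gaps separates it from the others: a 1.6-fold lower number from compound 1 to compound 3 (0.19 log units; within the scatter) and a 1.8-fold lower number from compound 2 to compound 3 (0.25 log units; within the scatter). The remaining pair is likewise close, a 1.2-fold higher number from compound 1 to compound 2 (0.06 log units; within the scatter).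

Compound 4 `C[Si](C)(C)c1cn(C[C@H](O)[C@H]2OC(=O)C(OCc3ccccc3)=C2OCc2ccccc2)nn1` has not yet been measured. It differs from compound 3 in one place: a group of 4 heavy atoms (3 carbon, 1 silicon; no ring) in place of a group of 12 heavy atoms (7 carbon, 1 nitrogen, 2 oxygen, 1 fluorine, 1 sulfur; one six-membered aromatic ring of carbon only), on an aromatic carbon. The three measured steps all exchange the group on that same aromatic carbon of the five-membered ring, and each of them stayed within the scatter. Among the compounds with values here, nothing among the measured compounds points to a change beyond the scatter for this further exchange, so no step beyond the scatter is expected in this assay, in either direction. Compound 4 is therefore estimated to give about 45000 nM in this assay, with a range from 20000 nM to 110000 nM. This estimate corresponds to an expected step of a 1.3-fold higher number from compound 3 to compound 4 (0.11 log units; within the scatter).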

Compound 4, half-maximal inhibitory concentration: 52600 nM
Compound 4: middle estimate off by 1.2-fold (0.07 log units), on the low side; measured number inside the range.
By their numbers in this assay, from the lowest: compounds 3, 4, 1 and 2 (each within the scatter of the next).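

In this assay, the aromatic carbon of the five-membered ring now carries a group with no ring at all, whereas the group there in each earlier compound held a six-membered aromatic ring of carbon only, and the steps remain small: a 1.5-fold higher number from compound 3 to compound 4 (0.18 log units; within the scatter), a 1.2-fold lower number from compound 2 to compound 4 (0.07 log units; within the scatter) and a 1.0-fold lower number from compound 1 to compound 4 (0.01 log units; within the scatter). Even the exchange of (((4-fluorophenyl)sulfonyl)amino)methyl, with 12 heavy atoms, 1 hydrogen-bond donor and 2 hydrogen-bond acceptors, for a group of 4 heavy atoms with neither donor nor acceptor stays within the scatter. No supporting evidence bears on why the number stays so close across these groups.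

The compounds shown contain no step beyond the scatter at this position, so what such a step would require remains unknown. On these data alone, whether an amine, a carboxylic acid or a longer alkyl chain on this carbon would separate from the four compounds also remains open.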